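The source may hold more compounds than are shown below. What is called first, only, known or untested is meant among the compounds shown, and "the series" means these compounds.

Measured compounds:
Compound 1 `c1ccc(COc2ccccc2Nc2ncnc3cc4c(cc23)OCCOCCOCCO4)cc1` gives 98400 nM in a functional assay on SH-SY5Y cells (Homo sapiens) for antiproliferative activity, read by MTT assay, with a stated time of 72 h; on this read-out higher numbers stand for weaker inhibition and lower numbers for stronger inhibition.
Compound 2 `FC(F)(F)c1ccc(COc2ccc(Nc3ncnc4cc5c(cc34)OCCOCCOCCOCCO5)cc2)cc1` gives 2140 nM in this assay.
Compound 3 `FC(F)(F)c1ccc(COc2cccc(Nc3ncnc4cc5c(cc34)OCCOCCO5)c2)cc1` gives 19300 nM in this assay.

Of the three, compound 2 stands lowest in this assay, and its distance to both compound 3 and compound 1 lies beyond the usual scatter. Among the compounds with values here, no pair among them differs in a single place, so no step can be named between them; only their values can be compared.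

Compound 4 `O=[N+]([O-])c1ccc(COc2ccc(Nc3ncnc4cc5c(cc34)OCCOCCOCCOCCO5)cc2)cc1` has not yet been measured in this assay. It differs from compound 2 by one change: nitro in place of trifluoromethyl on an aromatic carbon. Within the data shown here, with no measured step to guide the estimate, a small step is expected, in the direction of a slightly weaker number or none beyond the scatter, so that the step of a 1.4-fold higher number from compound 2 to compound 4 (0.15 log units; within the scatter) is estimated to be modest. Compound 4 is therefore expected to give about 3000 nM, within a range from 800 nM to 12000 nM.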

Compound 4, half-maximal inhibitory concentration: > 100000 nM
Compound 4: a limit, no number; the forecaster's own chance of this, stated with the estimate: 3%; middle value at least 33-fold (1.52 log units) away from the limit.
By their numbers in this assay, from the lowest: compound 2; then compound 3; then compound 1. At a limit, above all of these: compound 4.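

Nitro in place of trifluoromethyl gives the first step that can be read at a single place, and it is large: an at least 46-fold higher number from compound 2 to compound 4 (1.66 log units; beyond the scatter) in this assay. For compound 4 the value is a limit and not a number: the limit of > 100000 nM in this assay, at which 1 of the 4 values shown sits. Within the data shown here, the value of compound 2 therefore depends strongly on the group on this aromatic carbon, para to a large group, which the earlier compounds, differing in several places, could not show.

As far as these compounds go, how an amine or a nitrile on this carbon would stand remains open. So does whether the same change would act alike on the core and linkage of compound 3.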